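Furan-3-yl for thiophen-2-yl on two nucleoside cores

A few compounds are considered here, and "the series" means these few. Any claim that something is new, unique, unknown or untested is made for them only; others in the source may bear on it.

Compound 1 `CSc1ncnc2c1c(-c1ccoc1)cn2[C@@H]1O[C@H](CO)[C@@H](O)[C@H]1O`: in an ADME assay on MRC5 cells (Homo sapiens), read by MTT assay, with a stated time of 72 h (a higher number here means a weaker inhibitor, a lower number a stronger inhibitor), compound 1 gives > 100000 nM, which is a limit of the assay and not a number.
Compound 2 `CSc1ncnc2c1c(-c1cccs1)cn2[C@@H]1O[C@H](CO)[C@@H](O)[C@H]1O`: in this assay compound 2 gives > 100000 nM, likewise a limit.
Compound 3 `Nc1nc(N)c2c(-c3cccs3)cn([C@@H]3O[C@H](CO)[C@@H](O)[C@H]3O)c2n1`: in this assay compound 3 gives > 100000 nM, again a limit.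

The cores of compound 2 and compound 3 differ, but that difference between the two cores is not broken down here. From compound 2 to compound 1 the change is furan-3-yl in place of thiophen-2-yl on an aromatic carbon; the step it made is a step that the two limits leave unreadable from compound 2 to compound 1, unreadable because of the limit of > 100000 nM in this assay, at which 3 of the 3 values shown sit. For compound 3 only a limit is in hand, and the other two values shown are limits as well.

Compound 4 `Nc1nc(N)c2c(-c3ccoc3)cn([C@@H]3O[C@H](CO)[C@@H](O)[C@H]3O)c2n1` has not yet been measured in this assay. It arises from compound 3 by furan-3-yl in place of thiophen-2-yl on an aromatic carbon, the same change at the same place as the earlier one. Compound 4 is expected to give 150000 nM, with a range from 50000 nM to 500000 nM. The expected step is a step that the limit leaves unreadable from compound 3 to compound 4, small, standing beside the unreadable earlier one. That expectation rests on the value of compound 3, > 100000 nM, being a limit. It rests also on a step that the two limits leave unreadable from compound 2 to compound 1 giving no sign that the change lowers the value. Most likely the assay will again report only a limit for compound 4.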

Compound 4, half-maximal inhibitory concentration: > 100000 nM
Compound 4 was reported as a limit; the forecaster's own chance of this, stated with the estimate: 85%; the middle value is on the limit's open side.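

In this assay compound 4 gives > 100000 nM, which is a limit of the assay and not a number. Going by these compounds alone, no step from compound 3 to compound 4 can be read, because the value of each is only a limit: the limit of > 100000 nM in this assay, at which 4 of the 4 values shown sit. The compounds shown leave open whether furan-3-yl in place of thiophen-2-yl changes the value on either core.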